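Adding a Second Methoxy Group to a Benzothiazole Scaffold

The compounds below may be only part of what the source reports. "The series", "measured", "known", "first", "only" and "open" are said of these compounds alone.

Of the compounds shown here, two built on a shared core have been measured. Compound 1 `Cc1cc(-c2nc3ccccc3s2)ccc1-n1nnc2ccccc21` carries a methyl on its central ring, while compound 2 `COc1ccc2nc(-c3ccc(-n4nnc5ccccc54)cc3)sc2c1` instead bears a methoxy on the fused ring of the benzothiazole side. In a functional assay on Ca9-22 cells (Homo sapiens) for inhibition, read by wound healing assay, with stated times of 2 h and 16 h, tested at 2 uM (on this read-out higher numbers stand for more inhibition at the one concentration tested (going by the name of the read-out) and lower numbers for less inhibition), compound 1 gives 45.8% and compound 2 gives 68.7%. Compound 2 therefore stands highest of the two numbers shown, and the gap to compound 1 lies beyond the scatter of repeated measurements.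

Compound 3 `COc1ccc2c(c1)nnn2-c1ccc(-c2nc3ccc(OC)cc3s2)cc1` follows from compound 2 by a single change: methoxy in place of hydrogen on an aromatic carbon. The new group sits on an aromatic carbon of a six-membered aromatic ring of carbon only, part of a fused system of two rings, on the benzotriazole side of the molecule.

Among the compounds with values here, no measured pair in this set shows what such a methoxy for hydrogen exchange does, so the author expects a step from compound 2 to compound 3 of a number 1.3 percentage points higher from compound 2 to compound 3 (within the scatter) in this assay, a change not clearly beyond the scatter. On that basis compound 3 is estimated at 70%, with a range from 50% to 85%.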

Compound 3, a percentage reported as inhibition, at one concentration (the size of the read-out at that concentration, not a potency): 51.7%
For compound 3 the middle estimate is 18.3 percentage points above the measured one, and the stated range covers the measured number.
By their numbers in this assay, from the lowest: compounds 1 and 3 (each within the scatter of the next); then compound 2.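

Within the data shown here, this is the first reading in the set of what methoxy in place of hydrogen does. On an aromatic carbon of a six-membered aromatic ring of carbon only, part of a fused or bridged system of two rings, meta to a fused ring and para to a fused ring, the change gives a number 17 percentage points lower from compound 2 to compound 3 (beyond the scatter) in this assay. The position is therefore not indifferent to this exchange, since hydrogen there goes with more inhibition than methoxy at the one concentration tested, and the methoxy on compound 2 does not carry over into a further gain when a second one is placed here. Nothing measured in this set bears on why the step takes this direction.

On these data alone, whether a smaller atom such as fluorine, or a group such as an amine or a carboxylic acid, would read differently at this position remains open. So does whether methoxy would give a step of similar size on another carbon of the same ring, and whether the step seen at this single concentration would also hold at other concentrations.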